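The source may report more compounds than this note shows. Statements on the series, on what has been measured and on what is new or still open speak of the compounds shown alone.

Notes on the series. Compound 2 `Oc1nc2nonc2nc1Nc1ccccc1` carries the shared core with an unsubstituted phenyl on the amine. Among the compounds with values here, in an assay on mitochondria from L6 cells (Rattus norvegicus) for activation, with a stated time of 90 min (on this read-out higher numbers stand for an effect only at larger amounts of compound and lower numbers for an effect already at smaller amounts), compound 2 gives 66700 nM, the highest number of the two measured so far. Within the data shown here, its only measured neighbour is compound 1 `Oc1nc2nonc2nc1Nc1ccc(S(F)(F)(F)(F)F)cc1`, which in this assay gives 3900 nM; the step of a 17-fold higher number from compound 1 to compound 2 (1.23 log units; beyond the scatter) comes from a hydrogen atom in place of a group of 6 heavy atoms on an aromatic carbon.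

Compound 3 `CCc1ccc(Nc2nc3nonc3nc2O)cc1` differs from compound 2 by ethyl in place of hydrogen on an aromatic carbon. Among the measured compounds shown here, the one measured step that bears on this change is a 17-fold higher number from compound 1 to compound 2 (1.23 log units; beyond the scatter), where a larger group on the same ring went with a clearly lower number. Ethyl is a smaller group than the one lost between compound 1 and compound 2, so the return toward lower numbers is expected to be partial rather than complete. For compound 3 the estimated step is a 4.4-fold lower number from compound 2 to compound 3 (0.65 log units; beyond the scatter), a lower number, beyond the scatter but well short of the size of a 17-fold higher number from compound 1 to compound 2 (1.23 log units; beyond the scatter). Compound 3 is therefore estimated at 15000 nM in this assay, with a range of 5000 nM to 45000 nM.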

Compound 3, half-maximal effective concentration: 10700 nM
For compound 3 the middle estimate is 1.4-fold (0.15 log units) above the measured one, and the stated range covers the measured number.
By their numbers in this assay, from the lowest: compound 1; then compound 3; then compound 2.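

In this assay the step of a 6.2-fold lower number from compound 2 to compound 3 (0.79 log units; beyond the scatter) shows that, on this aromatic carbon para to a large group, the number can fall beyond the scatter without the group of 6 heavy atoms carried by compound 1: ethyl, with 2 carbon atoms, no ring and 0 hydrogen-bond donors or acceptors, is enough. The step of a 2.7-fold higher number from compound 1 to compound 3 (0.44 log units; beyond the scatter) also lies beyond the scatter, so the position separates ethyl from the group of 5 fluorine atoms and 1 sulfur atom, and the three compounds now form an order running from hydrogen through ethyl to that larger group, with none of them going against it. No measurement shown gives a reason for either step.

The compounds shown leave open whether this order holds for a longer chain such as butyl on the same carbon, or whether such a chain brings the number nearer to that of compound 1. They also leave open how an amine or a carboxylic acid at this position would compare with ethyl.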